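Swapping the methoxylated aryl ketone for a difluorinated one

The source may report more compounds than this note shows. Statements on the series, on what has been measured and on what is new or still open speak of the compounds shown alone.

The series is built around a shared core, seen in compound 1 `COc1ccc(C(=O)/C=C/c2cc(-c3cc(OC)c(OC)c(OC)c3)n[nH]2)cc1` and compound 2 `COc1ccc(C(=O)/C=C/c2cc(-c3cc(OC)c(OC)c(OC)c3)n[nH]2)cc1OC`. In a functional assay on 786-0 cells (Homo sapiens) for cytotoxicity, read by sulforhodamine B assay, with a stated time of 48 h, tested at 100 uM (a lower number here means a stronger effect, a higher number a weaker effect of the compound at the concentration tested), compound 1 gives -48%, and compound 2 gives -84%. Among the measured compounds shown here, compound 2 therefore stands lowest of the two numbers in this assay, with compound 1 as its nearest neighbour; the single measured step, a number 36 percentage points lower from compound 1 to compound 2 (beyond the scatter), came with a methoxy in place of hydrogen on an aromatic carbon.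

Compound 3 `COc1cc(-c2cc(/C=C/C(=O)c3ccc(F)c(F)c3)[nH]n2)cc(OC)c1OC` is the next step. Its change from compound 2 is 3,4-difluorophenyl in place of 3,4-dimethoxyphenyl on a carbonyl carbon. For the measured compounds named here, the only measured step that bears on it is the one from compound 1 to compound 2, which was large and downward when a methoxy was added to this same aryl group. The new change takes both methoxy groups away and brings fluorine in, so the step is expected to run in the other direction, with a fluorinated aryl of unknown effect adding uncertainty.

Compound 3 is therefore expected to give -40% in this assay, within a range of -75% to -5%, which means an expected step of a number 44 percentage points higher from compound 2 to compound 3 (beyond the scatter).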

Compound 3, a percentage reported as activity, at one concentration (the size of the read-out at that concentration, not a potency): -47%
The estimate for compound 3 lay 7 percentage points above the measured number; measured number inside the range.
By their numbers in this assay, from the lowest: compound 2; then compounds 1 and 3 (each within the scatter of the next).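

Among the compounds shown here, at this carbonyl carbon, the gain seen with 3,4-dimethoxyphenyl in this assay does not survive replacement by 3,4-difluorophenyl, with a number 37 percentage points higher from compound 2 to compound 3 (beyond the scatter); this is the first measured step in which that aryl group is exchanged whole rather than given one more methoxy. The comparison with the singly methoxylated aryl ketone gives a number 1 percentage points higher from compound 1 to compound 3 (within the scatter), so 3,4-difluorophenyl and 4-methoxyphenyl cannot be told apart here, and among these three compounds only the 3,4-dimethoxyphenyl of compound 2 stands apart from the others. No measurement in hand explains why the three aryl groups rank as they do.

The compounds shown leave open whether the fluorine atoms of compound 3 and the single methoxy of compound 1 contribute anything at all, since a plain phenyl on the carbonyl carbon would be needed as the reference for both. They also leave open whether the 3,4-dimethoxyphenyl result is specific to methoxy, which could be tested with a dimethylaminophenyl, a hydroxyphenyl or a longer ethoxy chain on the same aryl ring.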